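Triazole substituent swap on the butenolide series, compound 3

The source may report more compounds than this note shows. Statements on the series, on what has been measured and on what is new or still open speak of the compounds shown alone.

Two members of the series have been measured so far. Compound 1 `O=C1O[C@H]([C@@H](O)Cn2cc(-c3cccc(O)c3)nn2)C(OCc2ccccc2)=C1OCc1ccccc1` gives 51800 nM in a functional assay on MCF7 cells (Homo sapiens) for antiproliferative activity, read by MTT assay, with a stated time of 72 h (on this read-out higher numbers stand for weaker inhibition and lower numbers for stronger inhibition), and compound 2 `CCCCCc1ccc(-c2cn(C[C@H](O)[C@H]3OC(=O)C(OCc4ccccc4)=C3OCc3ccccc3)nn2)cc1` gives 9010 nM in the same assay. Within the data shown here, the single step connecting them, a 5.7-fold lower number from compound 1 to compound 2 (0.76 log units; beyond the scatter), is the only guide available; on it compound 2 stands with the lowest number of the two, compound 1 being its only neighbour.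

Compound 3 `O=C1O[C@H]([C@@H](O)Cn2cc(CNS(=O)(=O)c3ccc(F)cc3)nn2)C(OCc2ccccc2)=C1OCc1ccccc1` differs from compound 2 by the exchange ((((4-fluorophenyl)sulfonyl)amino)methyl in place of 4-pentylphenyl on an aromatic carbon). Among the measured compounds shown here, the one measured step moved from a ring bearing a hydroxyl to an all-carbon pentylphenyl and lowered the number. The change now made removes that pentylphenyl and brings in a group that counts 1 hydrogen-bond donor and 2 hydrogen-bond acceptors, so a reversal of the earlier step, of about the same size or smaller, is expected rather than a further drop. The step expected is a 3.3-fold higher number from compound 2 to compound 3 (0.52 log units; beyond the scatter), pointing to a higher number for compound 3. Compound 3 is therefore estimated at 30000 nM, with a range from 10000 nM to 90000 nM.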

Compound 3, half-maximal inhibitory concentration: 26800 nM
Compound 3: the middle estimate sits 1.1-fold (0.05 log units) above what was measured; low and high end bracket the measured number.
By their numbers in this assay, from the lowest: compound 2; then compounds 3 and 1 (each within the scatter of the next).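

In this assay, the exchange on the aromatic carbon of the five-membered aromatic ring with 3 nitrogen gives a 3.0-fold higher number from compound 2 to compound 3 (0.47 log units; beyond the scatter) and so shows that the earlier gain does not carry over to a second group of similar heavy-atom size that also contains one six-membered aromatic ring. Against the other earlier substituent, (((4-fluorophenyl)sulfonyl)amino)methyl gives a 1.9-fold lower number from compound 1 to compound 3 (0.29 log units; within the scatter), so this read-out does not separate it from 3-hydroxyphenyl, and among these three compounds only the all-carbon 4-pentylphenyl stands apart, a pattern that rests on that single compound. No measurement shown gives a reason for this separation.

The compounds shown leave open whether the pentyl chain itself matters or whether a plain phenyl or a butyl-substituted phenyl in the same place would match compound 2. They also leave open whether a phenyl bearing a carboxylic acid or an amine would group with compound 2 or with the other two compounds, and which part of the (((4-fluorophenyl)sulfonyl)amino)methyl group, if any, contributes to the value of compound 3.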